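The compounds below may be only part of what the source reports. "The series", "measured", "known", "first", "only" and "open" are said of these compounds alone.

Measured compounds:
- compound 1 `CCCC1=C(OCCC(C)C)C(CCC)(CCC)C(=O)/C(=C(O)\C=C\c2ccccc2)C1=O`: 15.3 uM
- compound 2 `CCCC1=C(OC)C(CCC)(CCC)C(=O)/C(=C(O)\C=C\c2ccc(Br)cc2)C1=O`: 2.6 uM
- compound 3 `CCCCC1=C(OC)C(CCCC)(CCCC)C(=O)/C(=C(O)\C=C\c2ccccc2)C1=O`: 7.8 uM

All three were tested in a functional assay on HCT-8 cells (Homo sapiens) for antiproliferative activity, read by sulforhodamine B assay, with a stated time of 3 days; on this read-out higher numbers stand for an effect only at larger amounts of compound and lower numbers for an effect already at smaller amounts. Compound 1 stands at the upper end of these numbers. Compound 3 lies within the scatter of it, while compound 2 lies lower, beyond the scatter.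

Compound 4 `CCCOC1=C(CCC)C(=O)/C(=C(O)/C=C/c2ccccc2)C(=O)C1(CCC)CCC` has not yet been measured. It carries methyl in place of isopropyl on a saturated chain carbon, two bonds along the chain from an oxygen on an unsaturated carbon, so that isopentyloxy becomes propoxy: methyl in place of isopropyl on a saturated chain carbon, two bonds along the chain from an oxygen on an unsaturated carbon. For the measured compounds named here, no two measured compounds differ in one place only, so no direct precedent exists, and no step beyond the scatter is expected in this assay. The expected change is a 1.4-fold lower number from compound 1 to compound 4 (0.14 log units; within the scatter). For compound 4 the estimated value is 11 uM, within an expected range of 5 uM to 24 uM.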

Compound 4, concentration for half-maximal effect: 2.6 uM
Estimate against measurement, compound 4: 4.2-fold (0.63 log units) above, outside the stated range (below it).
By their numbers in this assay, from the lowest: compounds 2 and 4 (each within the scatter of the next); then compounds 3 and 1 (each within the scatter of the next).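

In this assay, for the compounds shown here, isopentyloxy becoming propoxy gives a 5.9-fold lower number from compound 1 to compound 4 (0.77 log units; beyond the scatter) and provides the first comparison between compounds that differ in one place. It shows that this position is not indifferent to the change, as methyl in place of isopropyl on the saturated chain carbon moves the number beyond the scatter. No measurement shown accounts for this step. From the compounds shown here alone, whether an ethoxy or butoxy group at this position would follow the same direction remains open. So does whether a chain carrying an amine would be tolerated, or whether the step holds with other substituents on the shared core.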